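A few compounds are considered here, and "the series" means these few. Any claim that something is new, unique, unknown or untested is made for them only; others in the source may bear on it.

Measured compounds in an ADME assay on Vero cells (Chlorocebus sabaeus) for cytotoxicity, read by MTT assay, with a stated time of 72 h; a lower number here means a stronger inhibitor, a higher number a weaker inhibitor:
compound 1 `O=C(Nc1nc(-c2ccccc2)cs1)c1ccc([N+](=O)[O-])o1` gives 41700 nM;
compound 2 `O=C(Nc1nc(-c2cccc(OC3CCCC3)c2)cs1)c1ccc([N+](=O)[O-])o1` gives 81100 nM;
compound 3 `O=C(Nc1nc(-c2c(F)cc(F)cc2F)cs1)c1ccc([N+](=O)[O-])o1` gives 19900 nM.

Compound 2 stands highest of the three numbers in this assay. Its nearest neighbour is compound 1, and the step of a 1.9-fold higher number from compound 1 to compound 2 (0.29 log units; within the scatter) lies within the scatter; compound 3 stands furthest from it, beyond the scatter. Compound 4 `O=C(Nc1cccc(-c2csc(NC(=O)c3ccc([N+](=O)[O-])o3)n2)c1)c1ccccc1` differs from compound 2 by benzamido in place of cyclopentyloxy on an aromatic carbon. Among the compounds with values here, only one measured step bears on this position: the step of a 1.9-fold higher number from compound 1 to compound 2 (0.29 log units; within the scatter), which shows that a change at this aromatic carbon left the number within the scatter. On that basis compound 4 is expected to give 50000 nM in this assay, between 20000 nM and 150000 nM, so that the expected step of a 1.6-fold lower number from compound 2 to compound 4 (0.21 log units; within the scatter) lies within the scatter.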

Compound 4, half-maximal inhibitory concentration: 50200 nM
Beside the measured number, compound 4's estimate is 1.0-fold (0.00 log units) below it; the measured number falls inside the stated range.
By their numbers in this assay, from the lowest: compound 3; then compounds 1, 4 and 2 (each within the scatter of the next).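

In this assay, a group carrying an aromatic ring and an amide hydrogen replaces cyclopentyloxy without leaving the scatter (a 1.6-fold lower number from compound 2 to compound 4 (0.21 log units; within the scatter)). Benzamido in place of hydrogen also stays within the scatter (a 1.2-fold higher number from compound 1 to compound 4 (0.08 log units; within the scatter)), so this aromatic carbon, meta to a large group, has now taken two quite different groups with no step beyond the scatter. Nothing available explains why these numbers stay so close. Going by these compounds, whether an amine or a carboxylic acid at this carbon would give a step beyond the scatter remains open.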